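Swapping fluoro for hydroxy on an inactive sulfonamide

A few compounds are considered here, and "the series" means these few. Any claim that something is new, unique, unknown or untested is made for them only; others in the source may bear on it.

Compound 1 has the structure `O=S(=O)(Nc1ccc(-c2nc3ccccc3o2)cc1)c1cccc(F)c1`. In an assay on isolated protein for inhibition of malate dehydrogenase, mitochondrial (Sus scrofa), with stated times of 45 min and 30 min (on this read-out lower numbers stand for stronger inhibition and higher numbers for weaker inhibition), compound 1 gives only a limit, > 63000 nM, not a number. A second compound, compound 2 with the structure `O=S(=O)(Nc1ccc2oc(-c3ccccc3)nc2c1)c1cccc(C(F)(F)F)c1`, was tested in the same way. In this assay compound 2 also gives only a limit, > 63000 nM. Thus (the limit of > 63000 nM in this assay, at which 2 of the 2 values shown sit), so no inhibition is resolved for either compound, and no step between measured compounds can be stated.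

Compound 3, with the structure `O=S(=O)(Nc1ccc(-c2nc3ccccc3o2)cc1)c1cccc(O)c1`, has not yet been measured. It differs from compound 1 by hydroxy in place of fluoro on an aromatic carbon. For the measured compounds named here, no measured step shows what this exchange does, so the expectation rests on compound 1 alone, which sits at the limit with > 63000 nM. The step that the limit leaves unreadable from compound 1 to compound 3 is expected to be none beyond the scatter. Compound 3 is therefore estimated at 80000 nM, with a range from 30000 nM to 200000 nM in this assay.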

Compound 3, half-maximal inhibitory concentration: > 63000 nM
Compound 3: only a limit was reported (the forecaster's own chance of this, stated with the estimate: 85%); the middle value is on the limit's open side.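

In this assay compound 1 and compound 3 each give only a limit, so no step between them can be read: the limit of > 63000 nM in this assay, at which 3 of the 3 values shown sit.

The compounds shown leave open what hydroxy in place of fluoro does in a compound whose inhibition can be given as a number.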